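Methyl on Two Cores and Tolerance in Vero Cells

This account rests on a few compounds, and the source may have more. Where it says the series, first, only, none or still open, it means among the compounds named here.

Compound 1 `O=c1ccn(COC(CO)CO)c(=O)[nH]1`: in a functional assay on Vero cells (Chlorocebus sabaeus) for cytotoxicity (a higher number here means that more compound is tolerated, a lower number that less compound is tolerated), compound 1 gives > 462000 nM, which is a limit of the assay.
Compound 2 `Cc1cc(=O)[nH]c(=O)n1COC(CO)CO`: in this assay compound 2 gives > 434000 nM, again a limit.
Compound 3 `O=c1cnn(COC(CO)CO)c(=O)[nH]1`: in this assay compound 3 gives > 460000 nM, again a limit.

From compound 1 to compound 2 the change is methyl in place of hydrogen on an aromatic carbon. The step that the two limits leave unreadable from compound 1 to compound 2 cannot be sized because the limit of > 462000 nM in this assay, at which 1 of the 3 values shown sits, and the limit of > 434000 nM in this assay, at which 1 of the 3 values shown sits, are both limits. How the core of compound 3 differs from that of compound 1 is not broken down here. Compound 4 `Cc1nn(COC(CO)CO)c(=O)[nH]c1=O` has not yet been measured. It differs from compound 3 by methyl in place of hydrogen on an aromatic carbon. This is the same kind of change as from compound 1 to compound 2, but the surroundings differ: in compound 1 the ring has 2 nitrogen, and the carbon is ortho to a group of 7 heavy atoms, meta to two groups of 1 heavy atom each, opposite the ring nitrogen; in compound 3 the ring has 3 nitrogen, and the carbon is ortho to a group of 1 heavy atom, two atoms from the ring nitrogen, meta to a group of 7 heavy atoms, para to a group of 1 heavy atom. In this assay the step of an at least 1.0-fold lower number from compound 3 to compound 4 (0.00 log units; that floor lies within the scatter) is expected to be small, since compound 3 sits at the limit of > 460000 nM in this assay, at which 1 of the 3 values shown sits, and compound 2 likewise at a limit. Compound 4 is therefore estimated at 450000 nM, between 200000 nM and 500000 nM.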

Compound 4, half-maximal cytotoxic concentration: > 432000 nM
Compound 4 ended at the assay's limit; the forecaster's own chance of this, stated with the estimate: 85%; the middle value does not contradict the limit.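

In this assay compound 4 gives > 432000 nM, again a limit. Compound 3 also stands at a limit, and the size of the methyl step between compound 3 and compound 4 cannot be read. The compounds shown leave open whether methyl in place of hydrogen alters tolerance on either core, and at what concentration any of compounds 1 to 4 would harm these cells.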